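The compounds below may be only part of what the source reports. "The series", "measured", "known", "first", "only" and "open" are said of these compounds alone.

Measured in a functional assay on Jurkat cells (Homo sapiens) for inhibition, read by CCK-8 assay, with a stated time of 48 h; a lower number here means a stronger inhibitor of growth, a higher number a weaker inhibitor of growth:
- compound 1 `Cc1ccccc1Nc1nc(NC2CC2)ncc1Cl`: > 100000 nM
- compound 2 `Cc1ccccc1Nc1nc(Nc2ccccc2)ncc1Cl`: > 100000 nM
- compound 3 `Cc1ccccc1Nc1nc(NCc2ccccc2)ncc1Cl`: > 100000 nM

Each of these entries is a limit of the assay and not a number.

Compound 2 stands only at a limit, > 100000 nM. The other two compounds give it no numerical context, as the limit of > 100000 nM in this assay, at which 3 of the 3 values shown sit, shows.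

The next change leads to compound 4 `Cc1ccccc1Nc1nc(Nc2ccc(N3CCN(C)CC3)cc2)ncc1Cl`: 4-methylpiperazin-1-yl in place of hydrogen on an aromatic carbon. In words, 4-methylpiperazin-1-yl stands in place of hydrogen on an aromatic carbon, para to a large group.

Going by the values given here, three measured steps concern the neighbouring group on the same nitrogen-bearing position: a step that the two limits leave unreadable from compound 1 to compound 2, a step that the two limits leave unreadable from compound 1 to compound 3 and a step that the two limits leave unreadable from compound 2 to compound 3. None of them has a readable size, and none tests the new group, so they supply no size to carry over.

The expectation therefore rests on the structural change alone and is loose. In this assay, a move to a lower number is expected, though compound 4 may also end at a limit. The expected change is an at least 12-fold lower number from compound 2 to compound 4 (1.09 log units; beyond the scatter).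

For compound 4 the estimate is 8000 nM, with an expected range of 1000 nM to 60000 nM.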

Compound 4, concentration for 50% growth inhibition: 13700 nM
The estimate for compound 4 lay 1.7-fold (0.23 log units) below the measured number; low and high end bracket the measured number.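

In this assay, 4-methylpiperazin-1-yl in place of hydrogen on the aromatic carbon, para to a large group, gives an at least 7.2-fold lower number from compound 2 to compound 4 (0.86 log units; beyond the scatter). Compound 4 is the only compound shown with a readable number, so this position answers to substitution, whereas the steps among the cyclopropyl, phenyl and benzyl compounds cannot be read. The size of the step is only a bound, since compound 2 stands at a limit: the limit of > 100000 nM in this assay, at which 3 of the 4 values shown sit.

Going by these compounds, it remains open whether the whole 4-methylpiperazin-1-yl group is needed or whether a simpler amine such as dimethylamino, or a morpholine ring, would give a similar number. Also open, on these data alone, is how the number responds when the methyl on the piperazine ring gives way to a longer chain or a carboxylic acid.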